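Naphthalen-2-yl in place of the trifluoromethylphenyl group

The source may report more compounds than this note shows. Statements on the series, on what has been measured and on what is new or still open speak of the compounds shown alone.

Three measured compounds share one core and differ only in the group on the aromatic ring of the benzyl-type substituent. Compound 1 `COc1ccc(-c2ccc3c(c2)C(=O)C(=O)N3Cc2ccc(Cl)cc2)cc1` gives 350 nM in a functional assay on K562 cells (Homo sapiens) for antiproliferative activity, read by MTT assay, with a stated time of 48 h; on this read-out higher numbers stand for weaker inhibition and lower numbers for stronger inhibition. Compound 2 `COc1ccc(-c2ccc3c(c2)C(=O)C(=O)N3Cc2ccc(C#N)cc2)cc1` gives 380 nM in this assay, and compound 3 `COc1ccc(-c2ccc3c(c2)C(=O)C(=O)N3Cc2ccc(C(F)(F)F)cc2)cc1` gives 270 nM in this assay. The steps are small: a 1.1-fold higher number from compound 1 to compound 2 (0.04 log units; within the scatter), a 1.3-fold lower number from compound 1 to compound 3 (0.11 log units; within the scatter) and a 1.4-fold lower number from compound 2 to compound 3 (0.15 log units; within the scatter). Compound 3 has the lowest number of the three, but its gaps to compound 1 and to compound 2 are both within the scatter, so no ranking can be drawn from them.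

Compound 4 `COc1ccc(-c2ccc3c(c2)C(=O)C(=O)N3Cc2ccc3ccccc3c2)cc1` carries naphthalen-2-yl in place of 4-(trifluoromethyl)phenyl on a saturated chain carbon bound to an amide-type nitrogen in a ring. All three measured steps bear on this change only indirectly: each swaps one group on the same aromatic ring, and each stays within the scatter, whereas here the whole ring is exchanged for a fused pair of rings. Among the compounds with values here, no measured pair tests such an exchange. On the data at hand the expected change is a 1.1-fold higher number from compound 3 to compound 4 (0.05 log units; within the scatter), nothing beyond the scatter, with wide uncertainty. Compound 4 is therefore expected to give about 300 nM in this assay, with a range from 120 nM to 800 nM.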

Compound 4, half-maximal inhibitory concentration: 400 nM
Compound 4: middle estimate off by 1.3-fold (0.12 log units), on the low side; low and high end bracket the measured number.
By their numbers in this assay, from the lowest: compounds 3, 1, 2 and 4 (each within the scatter of the next).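

In this assay, exchanging the whole aromatic ring for a fused pair of rings on the saturated chain carbon bound to an amide-type nitrogen in a ring gives a 1.5-fold higher number from compound 3 to compound 4 (0.17 log units; within the scatter), a 1.1-fold higher number from compound 2 to compound 4 (0.02 log units; within the scatter) and a 1.1-fold higher number from compound 1 to compound 4 (0.06 log units; within the scatter). The earlier compounds shown here tested only a swap of one group on the same aromatic ring, whereas compound 4 shows that this position also accepts naphthalen-2-yl, with 2 six-membered aromatic rings of carbon only in place of one, and that the read-out cannot separate it from any of the other three compounds. No measurement at hand explains why these steps stay so small.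

As far as these compounds go, whether an amine or a carboxylic acid on the aromatic ring, or a longer chain in place of the saturated chain carbon, would produce a step beyond the scatter remains open. From the compounds shown here alone, the rest of the molecule is the same in all four compounds, so what a change in the shared core would do in this assay also remains open.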